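Cyclohexyl to benzyl at the boron-bearing carbon

The source may hold more compounds than are shown below. What is called first, only, known or untested is meant among the compounds shown, and "the series" means these compounds.

Two boronic acids were measured in an assay on isolated protein for inhibition of Lon protease homolog, mitochondrial (Homo sapiens), read by HTRF, with a stated time of 50 min, in the presence of a further agent that is not named here; a lower number here means a stronger inhibitor, a higher number a weaker inhibitor. Compound 1 `CC(C)C[C@H](NC(=O)[C@@H](C)NC(=O)c1cnccn1)B(O)O` gives 433 nM in this assay. Compound 2 `CCC[C@@H](NC(=O)c1cnccn1)C(=O)N[C@@H](CC1CCCCC1)B(O)O` gives 136 nM in this assay, the lower of the two numbers; the gap to compound 1 is beyond the usual scatter, so compound 2 stands as the stronger inhibitor of the pair.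

Compound 3 `CCC[C@@H](NC(=O)c1cnccn1)C(=O)N[C@@H](CCc1ccccc1)B(O)O` differs from compound 2 in one place: benzyl in place of cyclohexyl on a saturated chain carbon, two bonds along the chain from an amide-type nitrogen and a boron atom. Among the compounds with values here, no pair among the measured compounds shows this change, so nothing here tells how large the step should be. The expectation for compound 3 is a step of a 1.6-fold higher number from compound 2 to compound 3 (0.21 log units; within the scatter) that is small, at most a modest weakening, and may not reach beyond the scatter. Compound 3 is therefore estimated at 220 nM in this assay, within a range from 70 nM to 700 nM.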

Compound 3, half-maximal inhibitory concentration: 92 nM
The estimate for compound 3 lay 2.4-fold (0.38 log units) above the measured number; the measured number falls inside the stated range.
By their numbers in this assay, from the lowest: compounds 3 and 2 (each within the scatter of the next); then compound 1.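

In this assay the exchange of cyclohexyl for benzyl on a saturated chain carbon, two bonds along the chain from an amide-type nitrogen and a boron atom, gives a 1.5-fold lower number from compound 2 to compound 3 (0.17 log units; within the scatter) and so leaves compound 2 and compound 3 indistinguishable. Within the data shown here, this is the first reading of this change at this position, and it shows that, in this pair, the six-membered aromatic ring of carbon can take the place of the non-aromatic one without a step beyond the scatter. No evidence at hand bears on this result.

From the compounds shown here alone, whether a pyridine ring or a carboxylic acid on the ring at this position would read the same remains open. Also open, going by these compounds, is whether a longer chain carrying the phenyl ring would hold up in the same way.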